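Adding a hydroxy group to a compound at the assay limit

A few compounds are considered here, and "the series" means these few. Any claim that something is new, unique, unknown or untested is made for them only; others in the source may bear on it.

In an ADME assay on BJ cells (Homo sapiens) for cytotoxicity, with a stated time of 72 h (a lower number here means that less compound is needed, a higher number that more compound is needed for the effect), compound 1 `CCc1ccc(-c2nc3c(c(C)nn3-c3ccccc3)c(-c3ccccc3I)c2C#N)cc1`, which carries an iodo group, gives > 20000 nM, and this is a limit of the assay rather than a number. Compound 2 `CCc1ccc(-c2nc3c(c(C)nn3-c3ccccc3)c(-c3ccccc3C(=O)O)c2C#N)cc1`, which carries a carboxy group, gives > 20000 nM, also a limit. Compound 3 `CCc1ccc(-c2nc3c(c(C)nn3-c3ccccc3)c(-c3ccccc3)c2C#N)cc1`, which has hydrogen in that place, gives > 20000 nM, again a limit.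

Compound 4 `CCc1ccc(-c2nc3c(c(C)nn3-c3ccccc3)c(-c3ccc(O)cc3)c2C#N)cc1` differs from compound 3 by hydroxy in place of hydrogen on an aromatic carbon, so phenyl becomes 4-hydroxyphenyl. Three measured steps also swap a group on an aromatic carbon: a step that the two limits leave unreadable from compound 1 to compound 3, a step that the two limits leave unreadable from compound 1 to compound 2 and a step that the two limits leave unreadable from compound 2 to compound 3. None of them has a readable size, and the only visible pattern is the limit of > 20000 nM in this assay, at which 3 of the 3 values shown sit. Nothing therefore points to a change beyond the usual scatter in this assay, though limits can hide real differences. The expected step is a number no higher from compound 3 to compound 4 (the limit leaves the size open). Compound 4 is estimated at 20000 nM, with an expected range from 10000 nM to 40000 nM, and will most likely be reported as a limit again.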

Compound 4, half-maximal effective concentration: > 20000 nM
Compound 4 gave a limit, no number; the forecaster's own chance of this, stated with the estimate: 85%; the middle value sits exactly at the limit.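

Going by these compounds alone, compound 4 also gives only a limit, so no step from compound 1, compound 2 or compound 3 to compound 4 can be read in this assay. The compounds shown leave open whether any of these groups changes the concentration needed for the effect, because every value stands at the same limit: the limit of > 20000 nM in this assay, at which 4 of the 4 values shown sit.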